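Removing the (3-chlorophenyl)carbonyl group from compound 1

The compounds below may be only part of what the source reports. "The series", "measured", "known", "first", "only" and "open" are said of these compounds alone.

Compound 1 `O=C(Nc1ccccc1C(F)(F)F)C1CCc2ccccc2N1C(=O)c1cccc(Cl)c1` gives 288 nM in a functional assay on MDA-MB-231 cells (Homo sapiens) for cytotoxicity, read by sulforhodamine B assay, with a stated time of 72 h (a lower number here means a stronger inhibitor of growth, a higher number a weaker inhibitor of growth), the lowest of the two numbers reported; compound 2 `O=C(Nc1cc(C(F)(F)F)cc(C(F)(F)F)c1)C1CCc2ccccc2N1C(=O)c1ccc(Cl)cc1` gives 2000 nM, beyond the scatter above it. Compound 3 `CC(=O)N1c2ccccc2CCC1C(=O)Nc1cc(C(F)(F)F)cc(C(F)(F)F)c1` reaches only the limit of > 70000 nM in this assay. Going by the values given here, the single measured step that bears on the present change is an at least 35-fold higher number from compound 2 to compound 3 (1.54 log units; beyond the scatter), where putting methyl in place of 4-chlorophenyl on the carbonyl carbon cost at least that much. Compound 4 `O=C(Nc1ccccc1C(F)(F)F)C1CCc2ccccc2N1` differs from compound 1 by hydrogen in place of (3-chlorophenyl)carbonyl on a nitrogen on an aromatic ring in a ring, so the whole acyl group goes, not merely its 4-chlorophenyl part. A loss in this assay at least as large as that step is therefore expected, and compound 4 is likely to sit at or near (the limit of > 70000 nM in this assay, at which 1 of the 3 values shown sits). Compound 4 is expected at 40000 nM, between 5000 nM and 150000 nM. The expected step is a 140-fold higher number from compound 1 to compound 4 (2.14 log units; beyond the scatter).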

Compound 4, concentration for 50% growth inhibition: 45500 nM
Compound 4: the middle estimate sits 1.1-fold (0.06 log units) below what was measured; the range from low to high includes it.
By their numbers in this assay, from the lowest: compound 1; then compound 2; then compound 4. At a limit, above all of these: compound 3.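

With hydrogen in place of (3-chlorophenyl)carbonyl on this nitrogen, this assay shows a 160-fold higher number from compound 1 to compound 4 (2.20 log units; beyond the scatter), so the growth inhibition of compound 1 depends heavily on this acyl group. Compound 4 still gives a measured number rather than a limit. The only limit among the compounds shown belongs to compound 3: the limit of > 70000 nM in this assay, at which 1 of the 4 values shown sits.

On these data alone, it remains open whether an acetyl, a benzyl or a sulfonyl group on this nitrogen would recover any of the loss with the rest of compound 1 unchanged. As far as these compounds go, whether the chlorine itself contributes also remains open.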